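A few compounds are considered here, and "the series" means these few. Any claim that something is new, unique, unknown or untested is made for them only; others in the source may bear on it.

Measured compounds:
compound 1, `O=C1C(=O)N(CCCNc2ccnc3cc(C(F)(F)F)ccc23)c2cccc(Cl)c21`, 20200 nM
compound 2, `O=C1C(=O)N(CCCNc2ccnc3cc(C(F)(F)F)ccc23)c2cccc(Br)c21`, 33700 nM
compound 3, `O=C1C(=O)N(CCCNc2ccnc3cc(C(F)(F)F)ccc23)c2cc(Cl)ccc21`, 25200 nM

In an ADME assay on MCF-10A cells (Homo sapiens) for antiproliferative activity, read by sulforhodamine B assay, with a stated time of 48 h (a lower number here means a stronger inhibitor of growth, a higher number a weaker inhibitor of growth), compound 1 gives 20200 nM and compound 2 gives 33700 nM. The change between them is bromo in place of chloro on an aromatic carbon, and the step it made is a 1.7-fold higher number from compound 1 to compound 2 (0.22 log units; within the scatter). Compound 3 gives 25200 nM in this assay; the difference between its core and the core of compound 1 is not broken down here. Compound 4, `O=C1C(=O)N(CCCNc2ccnc3cc(C(F)(F)F)ccc23)c2cc(Br)ccc21`, has not yet been measured. It differs from compound 3 by bromo in place of chloro on an aromatic carbon. Among the measured compounds shown here, this is the same kind of change as the one from compound 1 to compound 2, not the same one: in the earlier pair the aromatic carbon is ortho to a fused ring and meta to a fused ring, whereas here it is meta to a fused ring and para to a fused ring. For the measured compounds named here, the step expected for compound 4 is a 1.4-fold higher number from compound 3 to compound 4 (0.15 log units; within the scatter), resting on the single earlier example a 1.7-fold higher number from compound 1 to compound 2 (0.22 log units; within the scatter). The value estimated for compound 4 in this assay is 36000 nM, expected to lie between 16000 nM and 80000 nM.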

Compound 4, concentration for 50% growth inhibition: 14600 nM
Compound 4: middle estimate off by 2.5-fold (0.39 log units), on the high side; measured number below the stated range.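

In this assay bromo in place of chloro on an aromatic carbon gives a 1.7-fold lower number from compound 3 to compound 4 (0.24 log units; within the scatter) and, set beside the earlier step, the change does not carry over as one fixed shift from core to core: the same change on two cores in this assay, a 1.7-fold higher number (0.22 log units; within the scatter) from compound 1 to compound 2 and a 1.7-fold lower number (0.24 log units; within the scatter) from compound 3 to compound 4, 2.9-fold (0.46 log units) apart, beyond the scatter of two such steps. Each step alone stays within the scatter, so neither shows by itself that bromo and chloro differ at that place; only the gap between the two steps goes beyond it. With a single pair on each core, the data do not show why the steps differ or whether another core would follow either one.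

The compounds shown leave open how fluoro, methoxy or a nitrile would behave at these places. Among the compounds shown here, they also leave open what a longer chain would do in place of the one present in these compounds.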